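Swapping an isopropyl for a methoxyphenyl on the ring amide

This account rests on a few compounds, and the source may have more. Where it says the series, first, only, none or still open, it means among the compounds named here.

Compound 1: `COc1ncc(-c2ccc3c(c2)N(c2ccc(Cl)cc2)C(=O)CO3)cc1NS(=O)(=O)c1ccc(F)cc1` — 4830 nM
Compound 2: `CC(C)N1C(=O)COc2ccc(-c3cccc(NS(=O)(=O)c4ccc(F)cc4)c3)cc21` — 22700 nM

In a functional assay on HeLa cells (Homo sapiens) for antiproliferative activity, read by MTT assay, with a stated time of 72 h (on this read-out lower numbers stand for stronger inhibition and higher numbers for weaker inhibition), compound 2 gives the highest of the two numbers; compound 1 gives a lower number, and that gap lies beyond the usual scatter. Compound 1 also carries an aryl group on its amide-type nitrogen, though it differs from compound 2 in more than one place. Compound 3, `COc1cccc(N2C(=O)COc3ccc(-c4cccc(NS(=O)(=O)c5ccc(F)cc5)c4)cc32)c1`, is still unmeasured. It differs from compound 2 by 3-methoxyphenyl in place of isopropyl on an amide-type nitrogen in a ring. A moderate step toward stronger inhibition is expected, a 2.8-fold lower number from compound 2 to compound 3 (0.45 log units; beyond the scatter), as compound 1 shows 4830 nM with an aryl at that nitrogen. Compound 3 is estimated at 8000 nM, within 2500 nM to 25000 nM.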

Compound 3, half-maximal inhibitory concentration: > 40000 nM
Compound 3 ended at the assay's limit; the forecaster's own chance of this, stated with the estimate: 5%; at least 5.0-fold (0.69 log units) between middle value and limit.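

In this assay compound 3 ends at a limit of the assay, not at a number: the limit of > 40000 nM in this assay, at which 1 of the 3 values shown sits.

Going by these compounds, putting 3-methoxyphenyl in place of isopropyl on this amide-type nitrogen gives an at least 1.7-fold higher number from compound 2 to compound 3 (0.24 log units; that floor lies within the scatter), and the true size of the step stays unknown. Compound 3 thus shows that an aryl group at this nitrogen does not by itself bring a lower number, which compound 1, differing in more than one place, could not show.

Open, on these data alone, is whether methyl, or a longer chain ending in an amine, at this nitrogen would give a lower number than compound 2.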